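This account rests on a few compounds, and the source may have more. Where it says the series, first, only, none or still open, it means among the compounds named here.

Three compounds have been measured in a functional assay on NCI-H460 cells (Homo sapiens) for inhibition, read by sulforhodamine B assay, with a stated time of 48 h; on this read-out higher numbers stand for weaker inhibition of growth and lower numbers for stronger inhibition of growth:

compound 1, `O=C1C=COC(/C=C/c2ccccc2)C1`, which gives 82.4 uM;
compound 2, `COc1ccc(/C=C/C2CC(=O)C=CO2)cc1`, which gives 149 uM;
compound 3, `COc1ccc(/C=C/c2cc(=O)cco2)cc1`, which gives 606 uM.

Compound 1 and compound 2 share a core and differ in one place: methoxy in place of hydrogen on an aromatic carbon. The step this made was a 1.8-fold higher number from compound 1 to compound 2 (0.26 log units; within the scatter), so the two values cannot be told apart with confidence. Compound 3 has a different core; the difference between the two cores is not broken down here. Its number is the highest of the three, and its distance from both compound 1 and compound 2 lies beyond the scatter.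

Compound 4, `COc1ccc(/C=C/c2cc(=O)cco2)cc1OC`, has not yet been measured. It differs from compound 3 by methoxy in place of hydrogen on an aromatic carbon. This is the same kind of change as that from compound 1 to compound 2, but not the same: in the earlier pair the new group sat para to a group of 9 heavy atoms, whereas here it sits ortho to a methoxy group and meta to a group of 9 heavy atoms, on a core that already gives a weaker read-out.

Because the earlier step of a 1.8-fold higher number from compound 1 to compound 2 (0.26 log units; within the scatter) stayed within the scatter, the expected step is a 1.3-fold higher number from compound 3 to compound 4 (0.12 log units; within the scatter). On this basis compound 4 is estimated at 800 uM in this assay, within a range from 350 uM to 2000 uM, with some chance that so weak an effect is reported only as a limit.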

Compound 4, concentration for growth inhibition (reported as GI): 546 uM
Compound 4: middle estimate off by 1.5-fold (0.17 log units), on the high side; the measured number falls inside the stated range.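

In this assay, placing a methoxy group ortho to a methoxy group and meta to a group of 9 heavy atoms gave a 1.1-fold lower number from compound 3 to compound 4 (0.05 log units; within the scatter), so compound 3 and compound 4 cannot be told apart with confidence. The same kind of change on the core of compound 1 gave a step that was also within the scatter, and the two steps cannot be told apart from each other: the same change on two cores in this assay, a 1.8-fold higher number (0.26 log units; within the scatter) from compound 1 to compound 2 and a 1.1-fold lower number (0.05 log units; within the scatter) from compound 3 to compound 4, 2.0-fold (0.30 log units) apart, within the scatter of two such steps. This shows that, in these two pairs, adding a methoxy group made no readable difference on either core, but it does not show a general rule, since it rests on two pairs with the new group in different places, and a real effect smaller than the scatter could go unseen in either pair.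

The aromatic ring in the compounds shown carries only hydrogen or methoxy, so it remains open whether a different group there, such as an amine, a carboxylic acid or a longer alkoxy chain, would give a step beyond the scatter. From the compounds shown here alone, it also remains open whether any such step would carry from one core to the other.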